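Working notes on a three-compound set and one pending analogue

The compounds below may be only part of what the source reports. "The series", "measured", "known", "first", "only" and "open" are said of these compounds alone.

compound 1, `O/N=C(\CCN1CCN(c2ncccn2)CC1)c1ccccc1`, in a functional assay on HEK293 cells with D(4) dopamine receptor (Homo sapiens) as the target, read by FLIPR; a higher number here means a larger maximal response, a lower number a smaller maximal response: 49%
compound 2, `O/N=C(\CCN1CCN(c2nccs2)CC1)c1ccccc1`, in this assay: 44%
compound 3, `CCO/N=C(\CCN1CCN(c2ncccn2)CC1)c1ccccc1`, in this assay: 26%

Compound 1 and compound 2 share one core and differ only in 1,3-thiazol-2-yl in place of pyrimidin-2-yl on an amine nitrogen in a ring. The step is a number 5 percentage points lower from compound 1 to compound 2 (within the scatter), so the two values are not told apart here.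

Compound 3 carries the core of compound 1 with a change at the oxygen, (ethyl in place of hydrogen on an oxygen). This step is larger, a number 23 percentage points lower from compound 1 to compound 3 (beyond the scatter), and compound 3 stands lowest of the three measured compounds, beyond the scatter against each of the other two.

Compound 4, `CCO/N=C(\CCN1CCN(c2nccs2)CC1)c1ccccc1`, is not yet measured. Against compound 3 it shows (1,3-thiazol-2-yl in place of pyrimidin-2-yl on an amine nitrogen in a ring). Among the measured compounds shown here, this is the same change as the one from compound 1 to compound 2: what leaves, what enters and the place around it read word for word alike. For the measured compounds named here, the one measured instance of this change, a number 5 percentage points lower from compound 1 to compound 2 (within the scatter), was within the scatter, so for compound 4 a step of about a number 5 percentage points lower from compound 3 to compound 4 (within the scatter) from compound 3 is expected, resting on that single earlier instance and on the value of compound 3, 26%. One prior occurrence is a thin basis, and the starting point of compound 3 is lower than that of compound 1, so the range is kept wide.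

For compound 4 in this assay the estimate is 21%, expected to fall between 8% and 34%.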

Compound 4, largest response reached (reported as efficacy), in percent of the reference or control that the assay uses: 72%
For compound 4 the middle estimate is 51 percentage points below the measured one; measured number above the stated range.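

In this assay the exchange of pyrimidin-2-yl for 1,3-thiazol-2-yl gives a number 46 percentage points higher from compound 3 to compound 4 (beyond the scatter) on the ethyl-bearing core, so this change does not carry over from the core of compound 1 to the core of compound 3: the same change on two cores in this assay, a number 5 percentage points lower (within the scatter) from compound 1 to compound 2 and a number 46 percentage points higher (beyond the scatter) from compound 3 to compound 4, 51 percentage points apart, beyond the scatter of two such steps.
Read along the other edge of the same set, ethyl in place of hydrogen on the oxygen gives a number 28 percentage points higher from compound 2 to compound 4 (beyond the scatter) with the 1,3-thiazol-2-yl group in place, which reverses the direction seen with pyrimidin-2-yl: the same change on two cores in this assay, a number 23 percentage points lower (beyond the scatter) from compound 1 to compound 3 and a number 28 percentage points higher (beyond the scatter) from compound 2 to compound 4, 51 percentage points apart, beyond the scatter of two such steps.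
The two changes therefore do not add up independently in these four compounds, but this is a single square with one instance of each step on each core, so it gives neither a reason for the reversal nor a rule for any other core.

The compounds shown leave open whether methyl on the oxygen, in place of ethyl, follows the hydrogen or the ethyl compounds, and whether pyridin-2-yl on the amine nitrogen in the ring behaves as 1,3-thiazol-2-yl or as pyrimidin-2-yl does. Also open, as far as these compounds go, is whether a longer chain on the oxygen, such as butyl, would keep the response that compound 4 shows at 72% or lose it.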